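Amide to urea: a change on the carbonyl carbon

The source may hold more compounds than are shown below. What is called first, only, known or untested is meant among the compounds shown, and "the series" means these compounds.

Measured so far in an ADME assay on MT4 cells (Homo sapiens) for cytotoxicity, read by MTT assay, with a stated time of 4 days; a lower number here means that less compound is tolerated, a higher number that more compound is tolerated:
- compound 1 `Cc1ccc(-c2c(C)c(-c3ccccc3)c(C(OC(C)(C)C)C(=O)O)c(C)c2NS(C)(=O)=O)cc1C`: > 50000 nM
- compound 2 `CC(=O)Nc1c(C)c(C(OC(C)(C)C)C(=O)O)c(-c2ccc(C)c(C)c2)c(C)c1-c1ccc(C)c(C)c1`: 19000 nM
- compound 3 `Cc1ccc(-c2c(C)c(-c3ccc(Cl)c(F)c3)c(C(OC(C)(C)C)C(=O)O)c(C)c2NS(C)(=O)=O)cc1C`: 22000 nM

Compound 1 gives only a limit, the top of the range this assay can report (the limit of > 50000 nM in this assay, at which 1 of the 3 values shown sits), so it is not a number to compare with. Of the two numbers, compound 2 and compound 3 sit within the usual scatter of each other, so neither can be called more or less tolerated than the other.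

Going by the values given here, the one measured step between compounds that differ in a single place is an at least 2.2-fold lower number from compound 1 to compound 3 (0.35 log units; beyond the scatter), where a 4-chloro-3-fluorophenyl replaces a phenyl on an aromatic carbon. It changes an aryl ring, not the acetamido group, and so gives no direct guide to the change at hand.

Compound 4 `CCNC(=O)Nc1c(C)c(C(OC(C)(C)C)C(=O)O)c(-c2ccc(C)c(C)c2)c(C)c1-c1ccc(C)c(C)c1` differs from compound 2 by ethylamino in place of methyl on a carbonyl carbon. Among the compounds with values here, since no measured step touches the carbonyl carbon, there is nothing here to point to a move in either direction, and compound 4 is expected to show no step beyond the scatter, that is no change at the digits printed from compound 2 to compound 4 (within the scatter). In this assay compound 4 is therefore estimated at 19000 nM, with a range from 8000 nM to 50000 nM.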

Compound 4, half-maximal cytotoxic concentration: 15000 nM
The estimate for compound 4 lay 1.3-fold (0.10 log units) above the measured number; the measured number falls inside the stated range.
By their numbers in this assay, from the lowest: compounds 4, 2 and 3 (each within the scatter of the next). At a limit, above all of these: compound 1.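

In this assay, going by these compounds alone, the first reading at this carbonyl carbon is a 1.3-fold lower number from compound 2 to compound 4 (0.10 log units; within the scatter), so the two numbers cannot be told apart, even though the swap of acetamido for (ethylcarbamoyl)amino adds a nitrogen, a hydrogen-bond donor and a longer group. The earlier step concerned only an aryl ring, so it said nothing about this place, whereas this pair shows that one such enlargement of the acetyl end gives no separable reading here, though it is a single pair on a single core. With no difference to explain, nothing given here offers a cause for the two numbers, and none is needed.

Still open, going by these compounds, is whether larger or differently built groups on this carbonyl carbon would stay as close to compound 2, such as a longer chain like hexylamino, a ring amine like morpholine, or a chain ending in a carboxylic acid. Also open, on these data alone, is whether the same ethylamino swap would read alike on a core carrying other aryl groups, such as the 4-chloro-3-fluorophenyl of compound 3.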